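The source may report more compounds than this note shows. Statements on the series, on what has been measured and on what is new or still open speak of the compounds shown alone.

In a functional assay on HCT-116 cells (Homo sapiens) for inhibition, read by MTT assay, with a stated time of 48 h (a lower number here means a stronger inhibitor, a higher number a weaker inhibitor), the measured compounds read as follows:
Compound 1 `COc1cc(-c2nnc(SC)n2-c2ccc(N(C)C)cc2)cc(OC)c1OC` reads > 60000 nM as a limit
Compound 2 `COc1cc(-c2nnc(SCC(=O)c3ccc(F)cc3)n2-c2ccc(N(C)C)cc2)cc(OC)c1OC` reads 31100 nM as a number
Compound 3 `COc1cc(-c2nnc(SCC(=O)C3CC3)n2-c2ccc(N(C)C)cc2)cc(OC)c1OC` reads > 60000 nM as a limit

Compound 3 stands only at a limit, with no number to step from. The main fact of the series is the limit of > 60000 nM in this assay, at which 2 of the 3 values shown sit, and only compound 2 carries a number.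

Compound 4 `CCOC(=O)CSc1nnc(-c2cc(OC)c(OC)c(OC)c2)n1-c1ccc(N(C)C)cc1` differs from compound 3 by ethoxy in place of cyclopropyl on a carbonyl carbon in one place, ethoxy in place of cyclopropyl on a carbonyl carbon.

Two measured steps can be read, an at least 1.9-fold lower number from compound 1 to compound 2 (0.28 log units; that floor lies within the scatter) and an at least 1.9-fold higher number from compound 2 to compound 3 (0.28 log units; that floor lies within the scatter) as well. The third, a step that the two limits leave unreadable from compound 1 to compound 3 here, gives no size. The closest reason for an expectation is compound 3 with its step of an at least 1.9-fold higher number from compound 2 to compound 3 (0.28 log units; that floor lies within the scatter) on the same carbonyl carbon.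

The expected step is an at least 1.0-fold lower number from compound 3 to compound 4 (0.03 log units; that floor lies within the scatter) and none beyond the scatter is expected in this assay with a further limit as the likely reading.

Compound 4 is estimated at 55000 nM with an expected range from 25000 nM to 120000 nM around it.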

Compound 4, half-maximal inhibitory concentration: > 60000 nM
Compound 4: no number, only a limit; the forecaster's own chance of this, stated with the estimate: 70%; middle value at least 1.0-fold (0.03 log units) away from the limit.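

In this assay compound 4 gives > 60000 nM, which is a limit and not a number. Ethoxy in place of 4-fluorophenyl on the carbonyl carbon gives an at least 1.9-fold higher number from compound 2 to compound 4 (0.28 log units; that floor lies within the scatter), while the steps to compound 4 from compound 1 and compound 3 join two limits and cannot be read. A second non-aromatic group on this carbonyl carbon, after the cyclopropyl of compound 3, thus also gives no number, and compound 2 remains the only compound with one: the limit of > 60000 nM in this assay, at which 3 of the 4 values shown sit.

From the compounds shown here alone, every readable floor lies within the scatter, so whether compound 2 truly differs from the compounds at the limit stays open. Also open, going by these compounds, is whether an amine or a 4-methoxyphenyl in place of ethoxy on the carbonyl carbon would give a number in this assay.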